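Cytotoxicity notes on the 4-bromophenyl to 3-cyanophenyl step

A few compounds are considered here, and "the series" means these few. Any claim that something is new, unique, unknown or untested is made for them only; others in the source may bear on it.

Two members of the series have been run in an ADME assay on MT4 cells (Homo sapiens) for cytotoxicity, read by MTT assay, with a stated time of 5 days; a lower number here means that less compound is tolerated, a higher number that more compound is tolerated. Compound 1 `N#Cc1ccc(Nc2nccc(OCc3ccc(Br)cc3)n2)cc1` gives 16000 nM in this assay, the lowest of the two numbers in hand. Compound 2 `COc1cc(COc2ccnc(Nc3ccc(C#N)cc3)n2)cc(OC)c1` gives 44200 nM in this assay, a value that stands apart from compound 1 by more than the usual scatter. Going by the values given here, no pair of measured compounds differs in a single place, so no measured step is available to anchor an expectation.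

Compound 3 `N#Cc1ccc(Nc2nccc(OCc3cccc(C#N)c3)n2)cc1` has not yet been measured. It differs from compound 1 as follows: 3-cyanophenyl in place of 4-bromophenyl on a saturated chain carbon bound to an oxygen on an aromatic ring. Among the compounds with values here, with no measured step for this kind of change, the step from compound 1 to compound 3 in this assay is expected to be small, within the scatter, in no set direction. Because compound 1 gives 16000 nM, compound 3 is expected at 20000 nM in this assay, with a range from 7000 nM to 60000 nM. The expected step is a 1.3-fold higher number from compound 1 to compound 3 (0.10 log units; within the scatter).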

Compound 3, half-maximal cytotoxic concentration: 4100 nM
The estimate for compound 3 lay 4.9-fold (0.69 log units) above the measured number; measured number below the stated range.
By their numbers in this assay, from the lowest: compound 3; then compound 1; then compound 2.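

In this assay, 3-cyanophenyl in place of 4-bromophenyl on a saturated chain carbon bound to an oxygen on an aromatic ring gives a 3.9-fold lower number from compound 1 to compound 3 (0.59 log units; beyond the scatter) and so marks less compound as tolerated. Going by these compounds alone, this is the first measured single-place step, and it shows that changing the aryl group at this position alone can move the number beyond the scatter. No measurement in hand accounts for the step, and the added nitrile and lost bromine remain a description of the change, not an explanation of it.

The two compounds leave open whether the step goes with the nitrile, the loss of bromine or the different arrangement of the ring substituent. A plain phenyl group at this position would give a reference for both groups, while an amine or a carboxylic acid on the ring would test how far the trend extends.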